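The compounds below may be only part of what the source reports. "The series", "measured", "known", "first", "only" and "open" are said of these compounds alone.

Going by the values given here, in an ADME assay on MT4 cells (Homo sapiens) for cytotoxicity, read by spectrophotometry, with a stated time of 5 days (a lower number here means that less compound is tolerated, a higher number that more compound is tolerated), compound 1 `CCn1cc(C(=O)O)c(=O)c2cc(F)c(N3CCN(CN4C(=O)/C(=N\NC(=S)NO)c5cc(C)ccc54)C(C)C3)c(F)c21` gives 244000 nM and compound 2 `CONC(=S)N/N=C1\C(=O)N(CN2CCN(c3c(F)cc4c(=O)c(C(=O)O)cn(C5CC5)c4c3OC)CC2C)c2ccc(F)cc21` gives 171000 nM (two numbers within the usual scatter of each other), so compound 1 stands level with the only other measured compound. Among the compounds with values here, these two differ in more than one place, so no measured single-place step is available to size a change. Compound 3 `CCn1cc(C(=O)O)c(=O)c2cc(F)c(N3CCN(CN4C(=O)/C(=N\NC(=S)NO)c5cc(Cl)ccc54)C(C)C3)c(F)c21` keeps the core of compound 1 and carries chloro in place of methyl on an aromatic carbon. Within the data shown here, with no measured precedent for this swap, no step beyond the scatter is expected in this assay and only a slight lean to a lower number. The estimated step runs a 1.2-fold lower number from compound 1 to compound 3 (0.09 log units; within the scatter) and stays within the scatter. This expectation rests only on compound 1 at 244000 nM as the starting number. For compound 3 the estimated value is 200000 nM within an expected range from 90000 nM as the lower end to 400000 nM as the upper end.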

Compound 3, half-maximal cytotoxic concentration: 209000 nM
The estimate for compound 3 lay 1.0-fold (0.02 log units) below the measured number, and the stated range covers the measured number.
By their numbers in this assay, from the lowest: compounds 2, 3 and 1 (each within the scatter of the next).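

In this assay, going by these compounds alone, chloro in place of methyl on an aromatic carbon gives a 1.2-fold lower number from compound 1 to compound 3 (0.07 log units; within the scatter), the first measured single-place step. On this six-membered aromatic ring of carbon only, part of a fused or bridged system of two rings, the exchange of one heavy atom for another therefore leaves compound 3 level with compound 1, and the read-out does not separate methyl from chloro here. No measured property bears on this result.

From the compounds shown here alone, whether an amine or a nitrile on this aromatic carbon would move the number beyond the scatter remains open. So does the effect of a longer chain such as propyl there, since the single step shown covers only a swap between two groups of one heavy atom.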